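Benzylsulfanyl amide series: oral artery read-out, next step

The compounds below may be only part of what the source reports. "The series", "measured", "known", "first", "only" and "open" are said of these compounds alone.

Measured so far:
compound 1, `COc1ccc(C2N=C(SCc3ccccc3)NC(C)=C2C(=O)Nc2ccc(F)cc2)cc1OC` — 11.8%
compound 2, `CC1=C(C(=O)Nc2ccc(Br)cc2)C(c2ccc(Cl)cc2Cl)N=C(SCc2ccccc2)N1` — 17.4%

Working notes. In a functional assay on the whole organism (artery, strain albino) with Rattus norvegicus as the target, with a stated time of 240 min, at a dose of 10 mg/kg by the oral route (on this read-out lower numbers stand for less inhibition and higher numbers for more inhibition at the one dose given (going by the name of the read-out)), compound 2 gives 17.4%. In this assay compound 1 gives 11.8%. The gap between these two numbers lies within the usual scatter of repeated measurements, so neither compound can be set ahead of the other on this read-out, and the two differ in several places at once, so no single structural change can be tied to the gap.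

The next compound to be measured is compound 3, `CC1=C(C(=O)Nc2ccc(Br)cc2)C(c2ccc(Cl)cc2Cl)N=C(SCc2ccccc2Cl)N1`. It differs from compound 2 in one place: chloro in place of hydrogen on an aromatic carbon.

Among the measured compounds shown here, no pair of measured compounds isolates this change, so there is no recorded step to lean on; the two measured compounds both carry the unsubstituted benzyl group. With only that to go on, the step from compound 2 to compound 3 in this assay is expected to be a number 0.6 percentage points higher from compound 2 to compound 3 (within the scatter), that is, no change beyond the scatter in either direction. Compound 3 is therefore estimated at 18%, with a range from 5% to 32%.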

Compound 3, a percentage reported as inhibition, in the whole organism at one dose (the size of the read-out at that dose, not a potency): 28.7%
Compound 3: the middle estimate sits 10.7 percentage points below what was measured; the measured number falls inside the stated range.
By their numbers in this assay, from the lowest: compounds 1 and 2 (each within the scatter of the next); then compound 3.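

Among the compounds shown here, the benzylsulfanyl group is the first place where a single change can be read: in this assay, going from benzyl to 2-chlorobenzyl gives a number 11.3 percentage points higher from compound 2 to compound 3 (beyond the scatter) with the rest of the structure held constant. Compound 1 and compound 2 both carry the unsubstituted benzyl group, so neither could show that this read-out responds to a change on that ring, and the present step is modest and rests on one pair of compounds. No measurement at hand accounts for the step, which therefore stands as an observation without an explanation.

It remains open whether the step belongs to chloro itself or to its place on the ring, since only the 2-chlorobenzyl group is shown here and neither a fluoro, methyl or methoxy group at that place nor a chloro elsewhere on that ring can be compared with it. Also open, going by these compounds, are whether the same change holds with the other substituents of compound 1, and what a longer chain between the sulfur and the ring, or an amine in place of the benzylsulfanyl group, would do.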